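This account rests on a few compounds, and the source may have more. Where it says the series, first, only, none or still open, it means among the compounds named here.

Measured compounds:
- compound 1 `CC1=C(N2CC2)C(=O)C(CC(C)OC(N)=O)=C(N2CC2)C1=O`: 5.18
- compound 2 `CCC1=C(N2CC2)C(=O)C(C(COC(N)=O)OC)=C(N2CC2)C1=O`: 4.92
- compound 3 `COC(CO)C1=C(N2CC2)C(=O)C(C)=C(N2CC2)C1=O`: 5.27

In a functional assay on L1210 cells (Mus musculus), with a stated time of 1 days (on this read-out lower numbers stand for lower potency and higher numbers for higher potency (the scale is a negative logarithm)), compound 1 gives the second highest of the three numbers, but all three lie within the scatter of one another: a number 0.09 log units higher from compound 1 to compound 3 (within the scatter), and compound 2 sits slightly lower, again within the scatter.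

Compound 4 `CC1=C(N2CC2)C(=O)C(COc2ccccc2)=C(N2CC2)C1=O` differs from compound 1 by a group of 7 heavy atoms (6 carbon, 1 oxygen; one six-membered aromatic ring of carbon only) in place of a group of 6 heavy atoms (3 carbon, 1 nitrogen, 2 oxygen; no ring), on a saturated chain carbon bound to a double-bonded ring carbon. For the measured compounds named here, the one measured step at this side of the core, from compound 1 to compound 3, swapped the chain bearing the carbamate for a smaller oxygen-bearing group and gave no change beyond the scatter. Going by the values given here, no measured step introduces a phenoxy group or any aromatic ring, so the change is untested here. On this basis the expected step is a number 0.02 log units higher from compound 1 to compound 4 (within the scatter), with no shift beyond the scatter. For compound 4 the estimate is 5.2, ranging from 4.7 to 5.7.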

Compound 4, logarithm of the reciprocal of the active concentration, log(1/C): 3.89
Beside the measured number, compound 4's estimate is 1.31 log units above it; measured number outside the range, below it.
By their numbers in this assay, from the lowest: compound 4; then compounds 2, 1 and 3 (each within the scatter of the next, the first and the last beyond it).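

At the saturated chain carbon bound to a double-bonded ring carbon, the group is not freely exchangeable in this assay: phenoxy entering in place of the group of compound 1 gives a number 1.29 log units lower from compound 1 to compound 4 (beyond the scatter). By contrast, the earlier change on this side of the core gave a number 0.09 log units higher from compound 1 to compound 3 (within the scatter). No measurement here bears on the reason for the drop.

The compounds shown leave open whether the aromatic ring itself or the loss of the hydrogen-bond donor goes with the lower number. A hydroxyl or a short methoxy group on that chain carbon would help to separate the two.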